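A second nitroxide on the succinate chain

This account rests on a few compounds, and the source may have more. Where it says the series, first, only, none or still open, it means among the compounds named here.

In a functional assay on RPMI-8226 cells (Homo sapiens) for cytotoxicity, read by MTT assay, with a stated time of 72 h (on this read-out higher numbers stand for weaker inhibition and lower numbers for stronger inhibition), compound 1 `Cc1c(C)c2c(c(C)c1OC(=O)CCC(=O)O)CCC(C)(C(=O)NC1CC(C)(C)N([O])C(C)(C)C1)O2` gives > 300000 nM, and this value is a limit of the assay, not a number. Going by the values given here, compound 2 `Cc1c(C)c2c(c(C)c1O)CCC(C)(C(=O)NC1CC(C)(C)N([O])C(C)(C)C1)O2` gives 39000 nM, the only true number available so far.

Compound 3 `Cc1c(C)c2c(c(C)c1OC(=O)CCC(=O)NC1CC(C)(C)N([O])C(C)(C)C1)CCC(C)(C(=O)NC1CC(C)(C)N([O])C(C)(C)C1)O2` keeps the ester chain of compound 1, but a group with one six-membered non-aromatic ring replaces the hydroxy on a carbonyl carbon (a group of 12 heavy atoms (9 carbon, 2 nitrogen, 1 oxygen; one six-membered non-aromatic ring with 1 hetero atom) in place of one oxygen atom, on a carbonyl carbon). Among the compounds with values here, one measured step bears on this change: an at least 7.6-fold lower number from compound 1 to compound 2 (0.88 log units; beyond the scatter). That step lies beyond the scatter and removes the whole (2-carboxyethyl)carbonyl from the oxygen on an aromatic ring, whereas compound 3 retains that chain and alters only its end. Within the data shown here, the step also starts from the limit of > 300000 nM in this assay, at which 1 of the 2 values shown sits, so its full size remains open, and no measured compound tests the new group directly.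

A move towards lower numbers in this assay is therefore expected, though with little certainty, and compound 2 at 39000 nM serves as the nearest guide. The estimated step is an at least 5.0-fold lower number from compound 1 to compound 3 (0.69 log units; beyond the scatter). For compound 3 the expected value is 60000 nM, with an estimated range from 15000 nM to 300000 nM.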

Compound 3, half-maximal inhibitory concentration: 68000 nM
Estimate against measurement, compound 3: 1.1-fold (0.05 log units) below; the range from low to high includes it.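

In this assay, the end of the chain proves to matter on its own: with the ester chain kept, a group of 12 heavy atoms in place of the hydroxy on the carbonyl carbon gives an at least 4.4-fold lower number from compound 1 to compound 3 (0.64 log units; beyond the scatter). The earlier step left the limit only by removing the whole (2-carboxyethyl)carbonyl, whereas compound 3 shows that the chain can stay and a true number can still be read. The value > 300000 nM for compound 1 is a limit of the assay and not a number, so the full size of this step stays unknown: the limit of > 300000 nM in this assay, at which 1 of the 3 values shown sits.

The compounds shown do not tell whether this particular group, with its six-membered non-aromatic ring, is what counts, or whether the loss of the hydroxy is enough, which a methyl ester or a simple methyl amide on the same carbonyl carbon would separate. They also leave open how the chain itself contributes, since neither a longer chain nor a shorter one between the two carbonyl carbons stands among them.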